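Chloro added beside the amide trifluoromethyl in the pyrazole series

The source may report more compounds than this note shows. Statements on the series, on what has been measured and on what is new or still open speak of the compounds shown alone.

Of the compounds shown here, two have numbers so far. Compound 1 `COc1cc(-c2nn(-c3cccc(NC(=O)Nc4cc(C(F)(F)F)cc(C(F)(F)F)c4)c3)cc2-c2ccncc2)ccc1Cl` carries a urea with a bis(trifluoromethyl)phenyl group; in a functional assay on MDA-MB-468 cells (Homo sapiens) for inhibition, read by sulforhodamine B assay, with a stated time of 48 h (a higher number here means a weaker inhibitor of growth, a lower number a stronger inhibitor of growth), compound 1 gives 1540 nM. Compound 2 `COc1cc(-c2nn(-c3cccc(NC(=O)c4cccc(C(F)(F)F)c4)c3)cc2-c2ccncc2)ccc1Cl` carries instead an amide from 3-(trifluoromethyl)benzoic acid, and in this assay compound 2 gives 4560 nM. Within the data shown here, compound 2 thus stands at the highest of the two numbers, with compound 1 the only neighbour and its number clearly lower, beyond the scatter. The urea and the amide differ in more than one place, so the two values show only where each compound sits.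

Compound 3 `COc1cc(-c2nn(-c3cccc(NC(=O)c4ccc(Cl)c(C(F)(F)F)c4)c3)cc2-c2ccncc2)ccc1Cl` keeps the amide of compound 2 and adds one atom: chloro in place of hydrogen on an aromatic carbon. Among the measured compounds shown here, no matched step of this kind has been measured, so the expectation rests on the structural change alone. A modest move to a lower number is expected, as a 1.8-fold lower number from compound 2 to compound 3 (0.26 log units; within the scatter), though a value within the scatter of compound 2 would not be surprising. Compound 3 is therefore estimated at 2500 nM, with a range from 900 nM to 7000 nM.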

Compound 3, concentration for total growth inhibition: > 32500 nM
Compound 3: no number, only a limit (the forecaster's own chance of this, stated with the estimate: 5%); middle value at least 13-fold (1.11 log units) away from the limit.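

The value of compound 3 in this assay is a limit and not a number: the limit of > 32500 nM in this assay, at which 1 of the 3 values shown sits.

Chloro in place of hydrogen on an aromatic carbon, ortho to a trifluoromethyl group and para to a large group, gives an at least 7.1-fold higher number from compound 2 to compound 3 (0.85 log units; beyond the scatter), the first step in the series that differs in one place only. Compounds 1 and 2 differ in more than one place and could only mark where each sits, whereas this step ties a loss of growth inhibition, beyond the scatter, to this one carbon of the amide's aryl group and to this one added atom. Going from 3-(trifluoromethyl)phenyl to 4-chloro-3-(trifluoromethyl)phenyl is therefore not a neutral change in this series, whatever the reason for the loss, which these data do not give.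

As far as these compounds go, whether the loss belongs to chloro itself or to any group at this carbon remains open, and fluoro, methyl, methoxy or an amine there would separate the two. Also open, from the compounds shown here alone, is whether the same chloro on the aryl group of a urea such as compound 1 would give a step of the same direction.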